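The compounds below may be only part of what the source reports. "The series", "measured", "known", "first", "only" and "open" are said of these compounds alone.

Measured so far:
compound 1 `Cc1nnc(SCC(=O)c2ccc(Cl)cc2)n1N1C(=O)c2ccccc2C1=O` — > 200000 nM
compound 2 `C#CCSc1nnc(-c2cc(OC)c(OC)c(OC)c2)n1N1C(=O)c2ccccc2C1=O` — > 200000 nM

In a functional assay on A549 cells (Homo sapiens) for cytotoxicity, read by MTT assay, with a stated time of 48 h (a lower number here means a stronger inhibitor, a higher number a weaker inhibitor), compound 2 gives no number, only the limit > 200000 nM. Compound 1 likewise reaches only the limit of this assay, > 200000 nM. For the measured compounds named here, both values shown thus sit at the limit of > 200000 nM in this assay, at which 2 of the 2 values shown sit, so no step between measured compounds can be drawn and no number for either compound is known.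

Compound 3 `COc1cc(-c2nnc(SCC(=O)c3ccccc3C)n2N2C(=O)c3ccccc3C2=O)cc(OC)c1OC` is not yet measured. It differs from compound 2 in one place: (2-methylphenyl)carbonyl in place of ethynyl on a saturated chain carbon bound to a sulfur. Compound 1, which also carries an aromatic ring joined through a carbonyl to the sulfur-bound chain carbon, gives only the limit > 200000 nM, which gives no ground to expect a shift in this assay beyond the scatter. The expected step is a number no higher from compound 2 to compound 3 (the limit leaves the size open), most likely none beyond the scatter. Compound 3 is expected to sit at about 200000 nM, within 50000 nM to 400000 nM, and will probably again be reported only as a limit.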

Compound 3, half-maximal inhibitory concentration: 144000 nM
For compound 3 the middle estimate is 1.4-fold (0.14 log units) above the measured one, and the stated range covers the measured number.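

In this assay, compound 3 is the only compound shown with a number rather than a limit, and (2-methylphenyl)carbonyl in place of ethynyl on a saturated chain carbon bound to a sulfur gives an at least 1.3-fold lower number from compound 2 to compound 3 (0.14 log units; that floor lies within the scatter). This position therefore takes the much larger group, with its aromatic ring and carbonyl, without the number rising. Going by these compounds, the step is only a floor, and its true size stays unknown, with one end of the pair resting on a limit: the limit of > 200000 nM in this assay, at which 2 of the 3 values shown sit.

It remains open whether the methyl on the phenyl ring contributes anything, as no matching compound with a plain phenylcarbonyl group is shown. On these data alone, it is also open whether an amine, a carboxylic acid or a longer alkyl chain at this position would move the number beyond the scatter.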